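This account rests on a few compounds, and the source may have more. Where it says the series, first, only, none or still open, it means among the compounds named here.

Measured in an ADME assay on MDCK cells (Canis lupus familiaris) for cytotoxicity, read by microscopy, with a stated time of 48 h; on this read-out lower numbers stand for higher toxicity in this test and higher numbers for lower toxicity in this test:
compound 1 `C[C@H]1[C@H](NCc2ccsc2)C[C@H]2C[C@@H]1C2(C)C` — in this assay compound 1 gives 50000 nM.
compound 2 `C[C@H]1[C@H](NCc2cncs2)C[C@H]2C[C@@H]1C2(C)C` — in this assay compound 2 gives > 100000 nM, a limit of the assay, not a number.
compound 3 `Cc1csc(CN[C@@H]2C[C@H]3C[C@@H]([C@H]2C)C3(C)C)c1` — in this assay compound 3 gives 12500 nM.

Compound 3 holds the lowest of the two numbers; the nearest is compound 1, with a 4.0-fold lower number from compound 1 to compound 3 (0.60 log units; beyond the scatter). Compound 4 `C[C@H]1[C@H](NCc2cnccn2)C[C@H]2C[C@@H]1C2(C)C` differs from compound 3 by pyrazin-2-yl in place of 4-methylthiophen-2-yl on a saturated chain carbon bound to an amine nitrogen. For the measured compounds named here, the steps that bear on this change are an at least 2.0-fold higher number from compound 1 to compound 2 (0.30 log units; that floor lies within the scatter) and an at least 8.0-fold lower number from compound 2 to compound 3 (0.90 log units; beyond the scatter): each exchange toward a ring with more nitrogen gave a higher number in this assay. For compound 4 the expected step is therefore a 4.0-fold higher number from compound 3 to compound 4 (0.60 log units; beyond the scatter), upward. The estimate for compound 4 in this assay is 50000 nM, within 12500 nM to 200000 nM.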

Compound 4, minimum cytotoxic concentration: > 100000 nM
Compound 4: no number, only a limit (the forecaster's own chance of this, stated with the estimate: 35%); at least 2.0-fold (0.30 log units) between middle value and limit.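

In this assay compound 4 gives > 100000 nM, a limit of the assay and not a number. Pyrazin-2-yl gives an at least 8.0-fold higher number from compound 3 to compound 4 (0.90 log units; beyond the scatter), and also an at least 2.0-fold higher number from compound 1 to compound 4 (0.30 log units; that floor lies within the scatter), so a six-membered aromatic ring with 2 hetero atoms at this place joins the five-membered 1,3-thiazol-5-yl at the top of the read-out. Any order between compound 2 and compound 4 cannot be read because both stand at the same limit: the limit of > 100000 nM in this assay, at which 2 of the 4 values shown sit.

Open, on these data alone, is whether phenyl at this place gives a readable number. Also open, as far as these compounds go, is whether the lower number of compound 3 goes with its methyl group or with the thiophene ring itself.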